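The source may hold more compounds than are shown below. What is called first, only, known or untested is meant among the compounds shown, and "the series" means these compounds.

Three compounds share one core and differ only in the group on the sulfonyl sulfur. Compound 1 `O=S(=O)(Nc1ccc(-c2nc3ccccc3o2)cc1)c1ccccc1O` carries 2-hydroxyphenyl there. In an assay on isolated protein for inhibition of malate dehydrogenase, mitochondrial (Sus scrofa), with stated times of 45 min and 30 min (a lower number here means a stronger inhibitor, a higher number a weaker inhibitor), compound 1 gives only a limit of the assay, > 63000 nM. Compound 2 `O=S(=O)(Nc1ccc(-c2nc3ccccc3o2)cc1)c1ccc(Cl)s1` carries 5-chlorothiophen-2-yl instead. In this assay compound 2 also reaches only a limit, > 63000 nM. Compound 3 `O=S(=O)(Nc1ccc(-c2nc3ccccc3o2)cc1)c1cccc(O)c1` carries 3-hydroxyphenyl. In this assay compound 3 likewise gives a limit, > 63000 nM. Because all three values sit at the same limit (the limit of > 63000 nM in this assay, at which 3 of the 3 values shown sit), none of the steps between them can be read: a step that the two limits leave unreadable from compound 1 to compound 2, a step that the two limits leave unreadable from compound 1 to compound 3 and a step that the two limits leave unreadable from compound 2 to compound 3. Compound 3 therefore stands nowhere distinguishable from compounds 1 and 2; all three are weak at best. Compound 4 `O=S(=O)(Nc1ccc(-c2nc3ccccc3o2)cc1)c1ccc(Cl)cc1` differs from compound 3 by 4-chlorophenyl in place of 3-hydroxyphenyl on a sulfonyl sulfur. Within the data shown here, no measured step informs this change in size or direction; every change tried so far on the sulfonyl sulfur left the value at the limit. The expected step is a number no higher from compound 3 to compound 4 (the limit leaves the size open). Compound 4 is expected to give 63000 nM, within 30000 nM to 200000 nM, most likely again only a limit.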

Compound 4, half-maximal inhibitory concentration: > 63000 nM
Compound 4 gave a limit, no number; the forecaster's own chance of this, stated with the estimate: 85%; the middle value sits exactly at the limit.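

Compound 4 gives only a limit, as do compounds 1, 2 and 3, so no step among these four compounds can be read: the limit of > 63000 nM in this assay, at which 4 of the 4 values shown sit.
In this assay the compounds shown leave open how strong each of the four actually is and whether changing the group on the sulfonyl sulfur makes any difference.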